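Solubility notes: trifluorophenyl analogue of compound 2

The compounds below may be only part of what the source reports. "The series", "measured", "known", "first", "only" and "open" are said of these compounds alone.

Within the data shown here, compound 2 `Cc1cc(NCc2ccccn2)n2ncc(-c3cccc(F)c3)c2n1` is the one member of the pair with a number in a physicochemical assay for solubility, read by HPLC, using the shake flask method, measured as kinetic solubility, with a stated time of 2 h, at pH 7.4; a higher number here means a more soluble compound, a lower number a less soluble compound: compound 2 gives 5000 nM. The other value is a limit of the assay and not a number: compound 1 `Cc1cc(NCc2ccccn2)n2ncc(-c3cccc(Cl)c3)c2n1` sits at < 5000 nM. Among the measured compounds shown here, the one measured step, a number no lower from compound 1 to compound 2 (the limit leaves the size open), is a fluoro in place of chloro on an aromatic carbon; its size cannot be read, because of the limit of < 5000 nM in this assay, at which 1 of the 2 values shown sits.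

Compound 3 `Cc1cc(NCc2ccccn2)n2ncc(-c3cc(F)c(F)c(F)c3)c2n1` differs from compound 2 by 3,4,5-trifluorophenyl in place of 3-fluorophenyl on an aromatic carbon. For the measured compounds named here, the only step that bears on it, a number no lower from compound 1 to compound 2 (the limit leaves the size open), exchanges a single halogen and leaves its size open, so it gives no measure of what two further fluorines on the same ring do to solubility. Going by the values given here, no measured step carries the trifluorophenyl group. The step of a 1.7-fold lower number from compound 2 to compound 3 (0.22 log units; within the scatter) is therefore expected to be small, with a fair chance that this assay reports only a limit rather than a number. The estimate for compound 3 is 3000 nM, between 1000 nM and 6000 nM.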

Compound 3, solubility: < 5000 nM
Compound 3 ended at the assay's limit (the forecaster's own chance of this, stated with the estimate: 60%); the middle value is on the limit's open side.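

The exchange of 3-fluorophenyl for 3,4,5-trifluorophenyl, on an aromatic carbon of a five-membered aromatic ring with 2 nitrogen, gives a number no higher from compound 2 to compound 3 (the limit leaves the size open) in this assay. Of the three aryl groups shown at this position, only the 3-fluorophenyl of compound 2 has a number, as the result for compound 3 is a limit and not a number. The sizes of the new steps cannot be read, because the values sit at a limit: the limit of < 5000 nM in this assay, at which 2 of the 3 values shown sit.

On these data alone, the order of compound 1 and compound 3, and how far either lies from compound 2, remain open. So does what an amine or a carboxylic acid on the same phenyl ring would give in this assay.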